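The source may report more compounds than this note shows. Statements on the series, on what has been measured and on what is new or still open speak of the compounds shown alone.

Measured compounds:
compound 1, `O=C(CCCCC1CCSS1)NCc1cn(CCCOc2ccc3cc(-c4ccccc4)c(=O)oc3c2)nn1`: 27.2% in a functional assay on PC-12 cells (Rattus norvegicus) for cytotoxicity, read by MTT assay, with stated times of 3 h and 2 h, tested at 20 uM; a higher number here means a stronger effect of the compound at the concentration tested, a lower number a weaker effect
compound 2, `O=C(CCCCC1CCSS1)NCc1cn(CCCCCOc2ccc3ccc(=O)oc3c2)nn1`: 78.5% in this assay
compound 3, `Cc1cc(=O)oc2cc(OCCCCCn3cc(CNC(=O)CCCCC4CCSS4)nn3)ccc12`: 70.3% in this assay

Among the three numbers, compound 2 stands highest in this assay. Its nearest neighbour is compound 3, and the step of a number 8.2 percentage points lower from compound 2 to compound 3 (within the scatter) lies within the scatter, so the two cannot be ordered. Among the compounds with values here, compound 1 stands far lower, with a gap to compound 2 that is beyond the scatter; no single-change step links these two, so only their two values can be compared.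

Compound 4, `O=C(CCCCC1CCSS1)NCc1cn(CCCCCOc2ccc3cc(-c4ccccc4)c(=O)oc3c2)nn1`, differs from compound 2 by phenyl in place of hydrogen on an aromatic carbon. Within the data shown here, the one measured step on the shared core, methyl in place of hydrogen on an aromatic carbon, was a number 8.2 percentage points lower from compound 2 to compound 3 (within the scatter) and stayed within the scatter. Compound 1, which also carries the phenyl but on a shorter chain, gave 27.2% in this assay, a low number. On that basis a downward step a number 30.5 percentage points lower from compound 2 to compound 4 (beyond the scatter) is expected, of uncertain size. Compound 4 is estimated at 48%, in the range 22% to 76%.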

Compound 4, a percentage reported as activity, at one concentration (the size of the read-out at that concentration, not a potency): 20.7%
Compound 4: middle estimate off by 27.3 percentage points, on the high side, outside the stated range (below it).
By their numbers in this assay, from the lowest: compounds 4 and 1 (each within the scatter of the next); then compounds 3 and 2 (each within the scatter of the next).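

In this assay, within the data shown here, phenyl in place of hydrogen on the aromatic carbon two atoms from the ring oxygen gives a number 57.8 percentage points lower from compound 2 to compound 4 (beyond the scatter) as the first single-change step on this core to lie beyond the scatter, while the methyl change gave only a number 8.2 percentage points lower from compound 2 to compound 3 (within the scatter) and left the order open. Compound 4 carries the same chain as compound 2, so the low number seen with the phenyl now has a matched partner without it, which compound 1 lacked. Compound 4 and compound 1 differ in chain length and stand within the scatter of each other, so these two numbers do not separate the shorter chain from the longer one.

Nothing measured here explains the step. From the compounds shown here alone, whether a methyl, or a phenyl bearing a carboxylic acid, on this same carbon would give a number near that of compound 2 or that of compound 4 stays open.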